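Aryl swap on the triazole nitrogen of compound 3

The source may report more compounds than this note shows. Statements on the series, on what has been measured and on what is new or still open speak of the compounds shown alone.

Among the measured compounds shown here, compound 3 `COc1cc2c(Oc3ccc(NC(=O)c4cn(-c5ccccc5C)nn4)cc3F)ccnc2cc1OCCCN1CCC(C)CC1` is the weakest inhibitor among the three measured members: in a functional assay on A549 cells (Homo sapiens) for cytotoxicity, read by MTT assay, with a stated time of 72 h (a higher number here means a weaker inhibitor, a lower number a stronger inhibitor), compound 3 gives 3500 nM. Compound 1 `COc1cc2c(Oc3ccc(NC(=O)c4cn(-c5ccccc5C)nn4)cc3F)ccnc2cc1OCCCN1CCCC1` gives 900 nM in this assay, and compound 2 `COc1cc2c(Oc3ccc(NC(=O)c4cn(-c5ccccc5Cl)nn4)cc3F)ccnc2cc1OCCCN1CCC(C)CC1` gives 370 nM. Both single-point steps into compound 3 move the number upward, a 3.9-fold higher number from compound 1 to compound 3 (0.59 log units; beyond the scatter) and a 9.5-fold higher number from compound 2 to compound 3 (0.98 log units; beyond the scatter), so compound 3 stands clearly apart at the top.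

Compound 4 `COc1cc2c(Oc3ccc(NC(=O)c4cn(-c5ccc(F)c(F)c5)nn4)cc3F)ccnc2cc1OCCCN1CCC(C)CC1` keeps the 4-methylpiperidin-1-yl chain of compound 3 and alters only the aryl group on the aromatic nitrogen of the five-membered aromatic ring with 3 nitrogen: 3,4-difluorophenyl in place of 2-methylphenyl on an aromatic nitrogen. The step that bears on this is a 9.5-fold higher number from compound 2 to compound 3 (0.98 log units; beyond the scatter), where a methyl replacing a chloro on that same aryl ring raised the number; the present change goes the other way, removing the methyl and bringing in fluorine, though at different ring positions, so the earlier step is a guide only in direction. A drop in this assay is therefore expected, of the order of a 3.9-fold lower number from compound 3 to compound 4 (0.59 log units; beyond the scatter), but smaller than the chloro-to-methyl step because a 9.5-fold higher number from compound 2 to compound 3 (0.98 log units; beyond the scatter) concerns a swap of groups on a single aromatic carbon whereas the present change also alters where the groups sit. For compound 4 the estimate in this assay is 900 nM, with a range from 300 nM to 2700 nM.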

Compound 4, half-maximal inhibitory concentration: 1460 nM
Beside the measured number, compound 4's estimate is 1.6-fold (0.21 log units) below it, and the stated range covers the measured number.
By their numbers in this assay, from the lowest: compound 2; then compounds 1 and 4 (each within the scatter of the next); then compound 3.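

With the 4-methylpiperidin-1-yl chain held fixed, the aryl group on the aromatic nitrogen now has three readings in this assay, and 3,4-difluorophenyl falls inside the span set by the other two: a 2.4-fold lower number from compound 3 to compound 4 (0.38 log units; beyond the scatter) on leaving 2-methylphenyl, and a 3.9-fold higher number from compound 2 to compound 4 (0.60 log units; beyond the scatter) on leaving 2-chlorophenyl. Both steps lie beyond the scatter, so the number at this position responds to a change in both the identity and the placing of the ring substituents, not only to a swap of groups on a single aromatic carbon. Nothing available accounts for this order of the three aryl groups.

The 3,4-difluorophenyl group changes the substituents and where they sit in one step, so the compounds shown leave open how much of each step belongs to either change, which a plain phenyl or a 2-fluorophenyl group on the same chain would help to separate. Also open, on these data alone, is whether the order of the aryl groups holds with the pyrrolidin-1-yl chain, which appears here only with 2-methylphenyl.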